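Swapping furan for thiophene on a shared core

The source may hold more compounds than are shown below. What is called first, only, known or untested is meant among the compounds shown, and "the series" means these compounds.

Three measured compounds share one core and differ only in the ester group. Compound 1 `CCCOC(=O)C1=C(C)N(C)C(=O)NC1c1ccco1` gives 8% in an assay on membranes from HeLa cells for displacement of a labelled ligand from adenosine receptor A3 (Homo sapiens), read by scintillation counting, with a stated time of 180 min, tested at 1 uM; on this read-out lower numbers stand for less inhibition and higher numbers for more inhibition at the one concentration tested (going by the name of the read-out). Compound 2 `CC1=C(C(=O)OCC(C)C)C(c2ccco2)NC(=O)N1C` gives 23% in this assay, and compound 3 `CC1=C(C(=O)OCc2ccccc2)C(c2ccco2)NC(=O)N1C` gives 11% in this assay. Among these three numbers compound 3 stands second highest; the closest to it is compound 1, with a number 3 percentage points higher from compound 1 to compound 3 (within the scatter), and the furthest is compound 2, with a number 12 percentage points lower from compound 2 to compound 3 (beyond the scatter). For the measured compounds named here, the one other step, a number 15 percentage points higher from compound 1 to compound 2 (beyond the scatter), also lies on the ester side of the molecule.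

Compound 4 `CC1=C(C(=O)OCc2ccccc2)C(c2cccs2)NC(=O)N1C` is not yet measured. It differs from compound 3 by thiophen-2-yl in place of furan-2-yl on a saturated ring carbon. Going by the values given here, none of the measured steps touches this part of the molecule: all three concern the ester, and the ring on the saturated ring carbon is the same in compounds 1, 2 and 3. Among the compounds with values here, no measured step therefore bears directly on this change, and the numbers give no direction for it. For compound 4 the expected step is no change at the digits printed from compound 3 to compound 4 (within the scatter), that is, none beyond the scatter. Compound 4 is estimated at 11% in this assay, within an expected range from 0% to 25%.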

Compound 4, a percentage reported as inhibition, at one concentration (the size of the read-out at that concentration, not a potency): 18%
The estimate for compound 4 lay 7 percentage points below the measured number; measured number inside the range.
By their numbers in this assay, from the lowest: compounds 1, 3, 4 and 2 (each within the scatter of the next, the first and the last beyond it).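

In this assay, for the compounds shown here, the ring on the saturated ring carbon now has its first measured step, a number 7 percentage points higher from compound 3 to compound 4 (within the scatter), whereas the earlier steps all concerned the ester. At this one concentration, then, exchanging furan-2-yl for thiophen-2-yl, two five-membered aromatic rings that differ only in having oxygen or sulfur as the hetero atom, gives no difference that can be told apart from the usual spread of repeated measurements, so this position accepts the swap with the ester of compound 3 in place. Nothing measured here offers an explanation for the small gap between the two numbers, and it should not be read as a real preference for either ring.

The compounds shown leave open whether the same swap would also give a step within the scatter with the ester of compound 2, which has the highest number of the series so far. They also leave open how this saturated ring carbon would respond to a larger change, such as a pyridin-2-yl ring, a ring carrying an amine, or a plain propyl chain in place of the aromatic ring.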